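A Hydroxy Group Added to the Cyclopropyl of Compound 2

This account rests on a few compounds, and the source may have more. Where it says the series, first, only, none or still open, it means among the compounds named here.

Compound 2 `COCc1cc(OC)c(-c2cccc3c(N(CC4CCOCC4)CC4CC4)c(SC)nn23)c(OC)c1` gives 35 nM in an assay on HEK293 cells for displacement of a labelled ligand from corticotropin-releasing factor receptor 1 (Homo sapiens), read by scintillation counting, with a stated time of 2 h; a lower number here means a stronger inhibitor, a higher number a weaker inhibitor.
Compound 3 `COCc1cc(OC)c(-c2cccc3c(N(CC4CCOCC4)CC4CC4)c(OC)nn23)c(OC)c1` gives 51 nM in this assay.
Compound 1 `COCc1cc(OC)c(-c2cccc3c(N(CC4CC4)CC4OCCCO4)c(SC)nn23)c(OC)c1` gives 113 nM in this assay.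

Compound 2 has the lowest number of the three, but only compound 1 is clearly apart from it: a 3.2-fold lower number from compound 1 to compound 2 (0.51 log units; beyond the scatter). Compound 3 is not, since a 1.5-fold higher number from compound 2 to compound 3 (0.16 log units; within the scatter).

Compound 4 `COCc1cc(OC)c(-c2cccc3c(N(CC4CCOCC4)CC4(O)CC4)c(SC)nn23)c(OC)c1` differs from compound 2 in one place: hydroxy in place of hydrogen on a saturated ring carbon. The two measured steps concern other parts of the molecule, one the six-membered ring on the chain at the ring nitrogen, the other the methylsulfanyl group, so neither tells directly how a hydroxy on the three-membered ring will be tolerated. Without such a guide, the reasonable expectation in this assay is a step that is either within the scatter or a mild move toward a higher number. The estimate for compound 4 is therefore 60 nM, with a range of 20 nM to 200 nM, which would mean a step of a 1.7-fold higher number from compound 2 to compound 4 (0.23 log units; within the scatter).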

Compound 4, half-maximal inhibitory concentration: 98 nM
Beside the measured number, compound 4's estimate is 1.6-fold (0.21 log units) below it; measured number inside the range.
By their numbers in this assay, from the lowest: compounds 2, 3, 4 and 1 (each within the scatter of the next, the first and the last beyond it).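

In this assay, hydroxy in place of hydrogen on a saturated ring carbon of the cyclopropyl gives a 2.8-fold higher number from compound 2 to compound 4 (0.45 log units; beyond the scatter). Going by these compounds alone, the earlier steps changed only the six-membered ring and the methylsulfanyl group, so this is the first sign that the three-membered ring also responds to a change, even one as small as a single added oxygen. The step is modest, and compound 4 still gives a measurable 98 nM, so the hydroxy is tolerated at a cost rather than ending inhibition, though nothing available here explains the rise.

On these data alone, it remains open whether a methyl, a fluorine or an amine on the same ring carbon would move the number as hydroxy does. Also open, as far as these compounds go, is whether hydroxy would produce a similar step with methoxy in place of methylsulfanyl.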